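Azidomethyl to diisopropylcarbamoyl on the shared core

The source may hold more compounds than are shown below. What is called first, only, known or untested is meant among the compounds shown, and "the series" means these compounds.

Of the compounds shown here, two have numbers so far. In a functional assay on A549 cells (Homo sapiens) for antiproliferative activity, read by MTT assay, with a stated time of 48 h (a higher number here means a weaker inhibitor, a lower number a stronger inhibitor), compound 1 (`COC/C1=C/C[C@](C)(CCC=C(C)C)/C=C/[C@@H](OC(=O)C=C(C)C)[C@](C)(O)/C=C/C1=O`) gives 3950 nM and compound 2 (`CC(C)=CCC[C@]1(C)/C=C/[C@@H](OC(=O)C=C(C)C)[C@](C)(O)/C=C/C(=O)/C(CN=[N+]=[N-])=C\C1`) gives 1720 nM as the lower of the two numbers. Among the compounds with values here, the only measured step is a 2.3-fold lower number from compound 1 to compound 2 (0.36 log units; beyond the scatter) and comes from azido in place of methoxy on a saturated chain carbon bound to a double-bonded ring carbon. It is modest but beyond the scatter.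

Compound 3 (`CC(C)=CCC[C@]1(C)/C=C/[C@@H](OC(=O)C=C(C)C)[C@](C)(O)/C=C/C(=O)/C(C(=O)N(C(C)C)C(C)C)=C\C1`) carries diisopropylcarbamoyl in place of azidomethyl on a double-bonded ring carbon. The measured step bears on this only loosely: it kept the saturated chain carbon, whereas here the whole azidomethyl leaves. No amide has been measured in the series. Within the data shown here, with compound 2 at 1720 nM as the lower of only two numbers, a modest step towards a higher number is expected in this assay although the direction remains uncertain. The expected step is a 2.0-fold higher number from compound 2 to compound 3 (0.31 log units; beyond the scatter) and is similar in size to the measured one. For compound 3 the estimated value is 3500 nM with an expected range from 1200 nM to 10000 nM in these notes.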

Compound 3, half-maximal inhibitory concentration: 13500 nM
For compound 3 the middle estimate is 3.9-fold (0.59 log units) below the measured one, outside the stated range (above it).
By their numbers in this assay, from the lowest: compound 2; then compound 1; then compound 3.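

In this assay, this position now shows a replacement that moves the number up on both sides: diisopropylcarbamoyl in place of azidomethyl gives a 7.8-fold higher number from compound 2 to compound 3 (0.89 log units; beyond the scatter), and diisopropylcarbamoyl in place of methoxymethyl gives a 3.4-fold higher number from compound 1 to compound 3 (0.53 log units; beyond the scatter). The two earlier compounds both keep a saturated chain carbon on the double-bonded ring carbon and are separated by the smaller 2.3-fold lower number from compound 1 to compound 2 (0.36 log units; beyond the scatter), so the choice of group at this position can shift the number further than that first pair suggested, and compound 3 has the highest number of the three. No measurement here gives a reason for this rise.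

The numbers cannot separate the loss of the saturated chain carbon from the entry of a group with 9 heavy atoms in place of 4, and a smaller amide such as dimethylcarbamoyl on the same carbon would bear on that. Also open, as far as these compounds go, is where an aminomethyl group or a carboxylic acid at this position would fall relative to compound 2 and compound 3, as three compounds in a single assay fix no trend.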